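Phenyl for dimethoxyphenyl on the ring nitrogen

A few compounds are considered here, and "the series" means these few. Any claim that something is new, unique, unknown or untested is made for them only; others in the source may bear on it.

The measured compounds so far:
compound 1, `COc1cccc(OC)c1N1C(=O)CSC1c1cccc(C(=O)NCCCCc2ccccc2)c1`, 31%
compound 2, `CCOc1ccccc1N1C(=O)C(C)SC1c1cccc(C(=O)NCCCCc2ccccc2)c1`, 53%
compound 3, `COc1ccccc1N1C(=O)CSC1C(=O)NCCCCc1ccccc1`, 4%

In a functional assay on 143B cells (Homo sapiens) for inhibition, read by CCK-8 assay, with a stated time of 72 h, tested at 1 uM (a higher number here means more inhibition at the concentration tested (going by the name of the read-out), a lower number less inhibition), compound 1 gives 31%, the second highest of the three numbers. Compound 2 lies higher by an amount beyond the scatter, and compound 3 lies lower by an amount beyond the scatter. Compound 4, `O=C(NCCCCc1ccccc1)c1cccc(C2SCC(=O)N2c2ccccc2)c1`, has not yet been measured. It differs from compound 1 in one place: phenyl in place of 2,6-dimethoxyphenyl on an amide-type nitrogen in a ring. Among the measured compounds shown here, the three measured values give no step for this change, so its size is uncertain. Compound 4 is expected to give 30% in this assay, with a range from 10% to 55%. The step from compound 1 expected by this estimate is a number 1 percentage points lower from compound 1 to compound 4 (within the scatter), within the scatter.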

Compound 4, a percentage reported as inhibition, at one concentration (the size of the read-out at that concentration, not a potency): 60%
Estimate against measurement, compound 4: 30 percentage points below, outside the stated range (above it).
By their numbers in this assay, from the lowest: compound 3; then compound 1; then compounds 2 and 4 (each within the scatter of the next).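

In this assay, phenyl in place of 2,6-dimethoxyphenyl on the amide-type nitrogen in the ring gives a number 29 percentage points higher from compound 1 to compound 4 (beyond the scatter). Among the compounds shown here, this is the first step that can be read at this position, and it shows that the group there affects inhibition. The two methoxy groups are also not needed for inhibition at the concentration tested. Nothing measured here gives a reason for this step.

The compounds shown leave open how a single methoxy, a fluorine, an amine or a carboxylic acid on this phenyl would compare with compound 4. They also leave open whether a change at this position would act in the same way on a different core.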